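Swapping the N-aryl group on a shared pyridazinone-amide core

The compounds below may be only part of what the source reports. "The series", "measured", "known", "first", "only" and "open" are said of these compounds alone.

Measured compounds:
compound 1: `COc1cc2c(Oc3ccc(NC(=O)c4nn(-c5ccccc5)c(=O)cc4C)cc3F)ccnc2cc1OCCCN1CCCCC1` — 160 nM
compound 2: `COc1cc2c(Oc3ccc(NC(=O)c4nn(-c5ccccc5OC(F)(F)F)c(=O)cc4C)cc3F)ccnc2cc1OCCCN1CCCCC1` — 40 nM
compound 3: `COc1cc2c(Oc3ccc(NC(=O)c4nn(-c5cccc(F)c5)c(=O)cc4C)cc3F)ccnc2cc1OCCCN1CCCCC1` — 130 nM

In a functional assay on MKN-45 cells (Homo sapiens) for inhibition, read by MTT assay, with a stated time of 72 h (a lower number here means a stronger inhibitor, a higher number a weaker inhibitor), compound 3 sits second highest among the three numbers shown; its nearest neighbour is compound 1, and the difference between them, a 1.2-fold lower number from compound 1 to compound 3 (0.09 log units; within the scatter), lies within the scatter, whereas compound 2 stands apart from it by a 3.3-fold higher number from compound 2 to compound 3 (0.51 log units; beyond the scatter).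

Compound 4 is `COc1ccc(-n2nc(C(=O)Nc3ccc(Oc4ccnc5cc(OCCCN6CCCCC6)c(OC)cc45)c(F)c3)c(C)cc2=O)cc1`. It differs from compound 3 in one place: 4-methoxyphenyl in place of 3-fluorophenyl on an aromatic nitrogen.

Two measured steps speak to this change. The step of a 4.0-fold lower number from compound 1 to compound 2 (0.60 log units; beyond the scatter) shows that a substituted phenyl on this nitrogen can lower the number beyond the scatter, while a 1.2-fold lower number from compound 1 to compound 3 (0.09 log units; within the scatter) shows that a fluoro at another position on that phenyl leaves the number essentially where it was. Within the data shown here, no measured compound carries a 4-methoxyphenyl, so the direction is uncertain. On this basis compound 4 is expected to remain near compound 3, with the step of a 1.3-fold lower number from compound 3 to compound 4 (0.11 log units; within the scatter) most likely within the scatter and an estimated value of 100 nM, in the range 35 nM to 300 nM.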

Compound 4, half-maximal inhibitory concentration: 330 nM
Beside the measured number, compound 4's estimate is 3.3-fold (0.52 log units) below it; the measured number lies above the stated range.
By their numbers in this assay, from the lowest: compound 2; then compounds 3 and 1 (each within the scatter of the next); then compound 4.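

In this assay, among these compounds, the 4-methoxyphenyl group is the first substituted phenyl here to raise the number from that of the plain phenyl beyond the scatter (a 2.1-fold higher number from compound 1 to compound 4 (0.31 log units; beyond the scatter)). It also stands apart from the other two substituted phenyls (a 2.5-fold higher number from compound 3 to compound 4 (0.40 log units; beyond the scatter); an 8.3-fold higher number from compound 2 to compound 4 (0.92 log units; beyond the scatter)), so across these four compounds a substituent on this phenyl can go either way: 2-(trifluoromethoxy)phenyl lowers the number, 4-methoxyphenyl raises it, and 3-fluorophenyl stays within the scatter of phenyl. Nothing measured here accounts for the rise with the 4-methoxyphenyl group.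

The compounds shown do not separate the effect of the methoxy group itself from the effect of where it sits on the phenyl. They also leave open how a dimethylamino group or a carboxylic acid would fare in its place.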